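Terphenyl-type hydroxyphenyl pyridines: cytotoxicity toward HCT-15

A few compounds are considered here, and "the series" means these few. Any claim that something is new, unique, unknown or untested is made for them only; others in the source may bear on it.

Measured so far:
compound 1 `Oc1ccc(-c2cc(-c3ccccc3O)cc(-c3cccc(O)c3)n2)cc1` — 4850 nM
compound 2 `Oc1ccc(-c2cc(-c3ccc(O)cc3)nc(-c3ccc(O)cc3)c2)cc1` — 5120 nM
compound 3 `Oc1ccc(-c2cc(-c3ccccc3O)cc(-c3ccccc3O)n2)cc1` — 8240 nM

In a functional assay on HCT-15 cells (Homo sapiens) for cytotoxicity, read by CCK-8 assay, with a stated time of 4 days (a lower number here means a stronger inhibitor, a higher number a weaker inhibitor), the three compounds lie close together. Compound 3 carries the highest number of the three, yet its nearest neighbour is compound 2, and both that gap and the gap to compound 1 fall within the scatter, so no ordering among them is claimed.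

The unmeasured compound 4 `Oc1ccc(-c2cc(-c3ccccc3O)cc(-c3ccc(O)cc3)n2)cc1` differs from compound 3 in one place: 4-hydroxyphenyl in place of 2-hydroxyphenyl on an aromatic carbon. Among the compounds with values here, the only measured step of a similar kind is a 1.7-fold higher number from compound 1 to compound 3 (0.23 log units; within the scatter), which exchanged one hydroxyphenyl for another on the shared core and stayed within the scatter. Compound 2, which carries 4-hydroxyphenyl throughout, and compound 3 also show values within the scatter of each other. Swapping one hydroxyphenyl for another therefore is not expected to move the number in this assay beyond the scatter, though a drift toward the values of compounds 1 and 2 is plausible.

Compound 4 is accordingly expected to give about 6000 nM, within 3000 nM to 12000 nM, which means an expected step of a 1.4-fold lower number from compound 3 to compound 4 (0.14 log units; within the scatter).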

Compound 4, half-maximal inhibitory concentration: 1920 nM
Estimate against measurement, compound 4: 3.1-fold (0.49 log units) above; measured number outside the range, below it.
By their numbers in this assay, from the lowest: compound 4; then compounds 1, 2 and 3 (each within the scatter of the next).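

In this assay the place next to the ring nitrogen turns out to respond to the hydroxyphenyl isomer: 4-hydroxyphenyl there gives a 4.3-fold lower number from compound 3 to compound 4 (0.63 log units; beyond the scatter) and also a 2.5-fold lower number from compound 1 to compound 4 (0.40 log units; beyond the scatter) while the exchange of 2-hydroxyphenyl and 3-hydroxyphenyl at this place had stayed within the scatter. More 4-hydroxyphenyl groups alone do not account for the pattern, and compound 2 goes against that reading, with a 2.7-fold lower number from compound 2 to compound 4 (0.43 log units; beyond the scatter) when a 2-hydroxyphenyl replaces a 4-hydroxyphenyl elsewhere on the shared core. No measurement at hand explains why this isomer stands apart.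

From the compounds shown here alone, whether the free hydroxyl of the 4-hydroxyphenyl group matters, as against a methoxy group, an amine or a carboxylic acid at the same ring position, remains open. Also open, going by these compounds, is how the 2-hydroxyphenyl group that compound 4 keeps contributes.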